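Swapping chloro for methoxy on a potent inhibitor

The compounds below may be only part of what the source reports. "The series", "measured", "known", "first", "only" and "open" are said of these compounds alone.

Compound 3, with the structure `CCCCN(CC)c1nc(C)nc2c1nc(Cl)n2-c1ccc(C(C)C)cc1Br`, is the strongest inhibitor among the three compounds that have been measured: in an assay on HEK293 cells for binding affinity to corticotropin-releasing factor receptor 1 (Homo sapiens), read by radioligand binding (a lower number here means a stronger inhibitor, a higher number a weaker inhibitor), compound 3 gives 1.5 nM. The next-nearest number belongs to compound 1, `CCCN(CC1CC1)c1nc(C)nc2c1n(C)c(=O)n2-c1ccc(C(C)C)cc1Br`, which in this assay gives 5.7 nM, a gap beyond the usual scatter. Far behind lies compound 2, `CCCN(CCC)c1nc(C)nc2c1n(C)c(=O)n2-c1c(C)cc(C)nc1C`, which in this assay gives 259 nM.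

Compound 4, `CCCCN(CC)c1nc(C)nc2c1nc(OC)n2-c1ccc(C(C)C)cc1Br`, differs from compound 3 in one place only: methoxy in place of chloro on an aromatic carbon. For the measured compounds named here, no measured pair in this set shows the same exchange, so no direct precedent tells how large the step should be. The change is small in size and keeps the rest of the molecule intact, so the expected step is modest, leaning towards a slightly weaker inhibitor, and it may well stay within the scatter. The expected step from compound 3 to compound 4 in this assay is a 2.3-fold higher number from compound 3 to compound 4 (0.37 log units; beyond the scatter). Compound 4 is therefore estimated to give 3.5 nM in this assay, with a likely range from 1 nM to 12 nM.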

Compound 4, inhibition constant: 1.5 nM
Compound 4: the middle estimate sits 2.3-fold (0.37 log units) above what was measured, within the range that was stated.
By their numbers in this assay, from the lowest: compounds 3 and 4 (each within the scatter of the next); then compound 1; then compound 2.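

In this assay, the exchange of chloro for methoxy gives no change at the digits printed from compound 3 to compound 4 (within the scatter), so on this aromatic carbon between two ring nitrogen atoms, a group of 2 heavy atoms with 1 hydrogen-bond acceptor can replace a single chlorine atom with no loss of binding beyond the scatter. For the compounds shown here, this is the first pair in the set that differs in one place, and so the first direct reading of any single change, since the earlier compounds differ from one another in more than one place. Nothing available explains why the two groups give matching numbers.

From the compounds shown here alone, it remains open how far this tolerance extends, for example to an amine, a carboxylic acid or a longer alkoxy chain such as butoxy at this position. One pair also cannot show whether the same exchange would behave alike on a different core.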